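Chloro for methyl on the shared core of compound 3

The source may report more compounds than this note shows. Statements on the series, on what has been measured and on what is new or still open speak of the compounds shown alone.

Measured compounds:
- compound 1 `O=c1c2ccccc2ccn1[C@@H]1O[C@H](COP(=O)(O)OP(=O)(O)OP(=O)(O)O)[C@@H](O)[C@H]1O`: 31 nM
- compound 2 `Cc1cn([C@@H]2O[C@H](COP(=O)(O)OP(=O)(O)OP(=O)(O)O)[C@@H](O)[C@H]2O)c(=O)c2ccccc12`: 17500 nM
- compound 3 `Cc1ccc2ccn([C@@H]3O[C@H](COP(=O)(O)OP(=O)(O)OP(=O)(O)O)[C@@H](O)[C@H]3O)c(=O)c2c1`: 148 nM

In a functional assay for agonist activity at P2Y purinoceptor 2 (Homo sapiens), read by FLIPR (a lower number here means that less compound is needed, a higher number that more compound is needed for the effect), compound 1 gives 31 nM. Compound 2 gives 17500 nM in this assay, and compound 3 gives 148 nM. Compound 3 thus stands second highest of the three numbers: nearest to compound 1, with a step of a 4.8-fold higher number from compound 1 to compound 3 (0.68 log units; beyond the scatter), and far from compound 2, whose number lies well beyond the scatter above that of compound 3.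

Compound 4 `O=c1c2cc(Cl)ccc2ccn1[C@@H]1O[C@H](COP(=O)(O)OP(=O)(O)OP(=O)(O)O)[C@@H](O)[C@H]1O` differs from compound 3 by chloro in place of methyl on an aromatic carbon. Among the measured compounds shown here, no measured step replaces methyl with chloro, so the only bearing comes from the two methyl-for-hydrogen steps: a 4.8-fold higher number from compound 1 to compound 3 (0.68 log units; beyond the scatter) at the carbon that now carries the chloro, and a 560-fold higher number from compound 1 to compound 2 (2.75 log units; beyond the scatter) at a different carbon. The first shows that a one-heavy-atom group at this carbon costs only a modest amount; chloro is of the same size as methyl, so compound 4 is expected to sit near compound 3, a step of a 1.2-fold lower number from compound 3 to compound 4 (0.09 log units; within the scatter) that is expected to stay within the scatter. For compound 4 the estimate in this assay is 120 nM, with a range from 40 nM to 400 nM.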

Compound 4, half-maximal effective concentration: 10 nM
Compound 4: the middle estimate sits 12-fold (1.08 log units) above what was measured, and the stated range ends above it.
By their numbers in this assay, from the lowest: compound 4; then compound 1; then compound 3; then compound 2.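

In this assay the outcome at this aromatic carbon depends on the group and not on its heavy-atom count alone: methyl and chloro each count one heavy atom, yet the change to chloro gives a 15-fold lower number from compound 3 to compound 4 (1.17 log units; beyond the scatter) in this series. Substitution here can also lower the number relative to hydrogen, as chloro gives a 3.1-fold lower number from compound 1 to compound 4 (0.49 log units; beyond the scatter) whereas methyl gives a 4.8-fold higher number from compound 1 to compound 3 (0.68 log units; beyond the scatter) at the same carbon. The data at hand offer no explanation for this split between chloro and methyl.

Open, on these data alone, is how other groups at this carbon would behave, such as fluoro, bromo, methoxy or an amine, and whether chloro is unusual among them. Also open, as far as these compounds go, is whether chloro would fare any better than methyl at the carbon substituted in compound 2.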